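The compounds below may be only part of what the source reports. "The series", "measured", "known", "first", "only" and "open" are said of these compounds alone.

Measured compounds:
Compound 1 `COc1cc(OC)c(OC)cc1/C=C/COC(=O)/C=C/c1ccc(OC)c(OC)c1` gives 173 mg/kg
Compound 2 `COc1cc(OC)c(OC)cc1/C=C/COC(=O)/C=C/c1ccc(F)cc1` gives 167 mg/kg

Going by the values given here, in a functional assay on the whole organism (strain Kunming) with Mus musculus as the target, with a stated time of 0.5 h (on this read-out higher numbers stand for an effect only at larger amounts of compound and lower numbers for an effect already at smaller amounts), compound 2 gives 167 mg/kg and sits level with compound 1, its only measured neighbour. Compound 3 (`COc1cc(OC)c(OC)cc1/C=C/COC(=O)/C=C/c1ccc(Cl)cc1`) differs from compound 2 in one place, with chloro in place of fluoro on an aromatic carbon. Among the compounds with values here, only one measured step bears on this: replacing 3,4-dimethoxyphenyl with 4-fluorophenyl gave a 1.0-fold lower number from compound 1 to compound 2 (0.02 log units; within the scatter), and no measured pair swaps fluoro for chloro directly. Little movement is therefore expected in this assay, with an expected 1.0-fold lower number from compound 2 to compound 3 (0.02 log units; within the scatter) that stays within the usual scatter. Compound 3 is estimated at 160 mg/kg, with an expected range from 95 mg/kg to 270 mg/kg.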

Compound 3, dose for half-maximal effect: 142 mg/kg
For compound 3 the middle estimate is 1.1-fold (0.05 log units) above the measured one; low and high end bracket the measured number.
By their numbers in this assay, from the lowest: compounds 3, 2 and 1 (each within the scatter of the next).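

In this assay, chloro in place of fluoro on an aromatic carbon para to a large group gives a 1.2-fold lower number from compound 2 to compound 3 (0.07 log units; within the scatter), so the two halogens cannot be told apart at this position. Replacing the whole 3,4-dimethoxyphenyl with 4-chlorophenyl gives a 1.2-fold lower number from compound 1 to compound 3 (0.09 log units; within the scatter), which is again within the scatter, so all three compounds read alike. No measurement shown offers a cause for this flat result.

As far as these compounds go, whether an amine or a carboxylic acid at this position would move the number beyond the scatter remains open. So does the effect of changing the ester link or the trimethoxyphenyl end.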